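A few compounds are considered here, and "the series" means these few. Any claim that something is new, unique, unknown or untested is made for them only; others in the source may bear on it.

Measured so far in a functional assay on MDA-MB-231 cells (Homo sapiens) for antiproliferative activity, read by CCK-8 assay, with a stated time of 72 h; on this read-out higher numbers stand for weaker inhibition and lower numbers for stronger inhibition:
compound 1 `O=C(Nc1cccc(-c2oc3cc(-c4ccc(F)cc4)ccc3c(=O)c2O)c1)c1ccc(Cl)cc1` — 12800 nM
compound 2 `O=C(Nc1cccc(-c2oc3cc(-c4ccc(F)cc4)ccc3c(=O)c2O)c1)c1ccc(F)cc1F` — 11200 nM

Compound 2 gives the lowest of these two numbers, yet it stands very close to compound 1: the step of a 1.1-fold lower number from compound 1 to compound 2 (0.06 log units; within the scatter) is within the usual scatter, so the two compounds cannot be told apart on this read-out.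

Compound 3 `COc1ccccc1C(=O)Nc1cccc(-c2oc3cc(-c4ccc(F)cc4)ccc3c(=O)c2O)c1` has not been measured yet. Compared with compound 2 the change is 2-methoxyphenyl in place of 2,4-difluorophenyl on a carbonyl carbon. Among the measured compounds shown here, the only measured step that bears on this is the one from compound 1 to compound 2, which also exchanged the aryl group attached to the same carbonyl carbon and produced no change beyond the scatter. On that single precedent, the swap to 2-methoxyphenyl is expected to leave the number in this assay essentially where compound 2 sits, with no step beyond the scatter in either direction; the expected step is a 1.0-fold higher number from compound 2 to compound 3 (0.01 log units; within the scatter). Compound 3 is therefore estimated at 11500 nM, with a range from 4500 nM to 30000 nM.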

Compound 3, half-maximal inhibitory concentration: 5110 nM
The estimate for compound 3 lay 2.3-fold (0.35 log units) above the measured number; measured number inside the range.
By their numbers in this assay, from the lowest: compound 3; then compounds 2 and 1 (each within the scatter of the next).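

In this assay, the aryl group on this carbonyl carbon does make a difference after all, since there is a 2.2-fold lower number from compound 2 to compound 3 (0.34 log units; beyond the scatter) and also a 2.5-fold lower number from compound 1 to compound 3 (0.40 log units; beyond the scatter). Both steps are modest but lie beyond the scatter, whereas the earlier exchange of 4-chlorophenyl for 2,4-difluorophenyl gave two compounds that could not be told apart. The change to compound 3 keeps the count of 8 heavy atoms and adds 1 hydrogen-bond acceptor, but nothing available explains why the number fell.

The compounds shown leave open whether the methoxy group itself matters, as a 2-hydroxyphenyl or a 2-methylphenyl on the same carbonyl carbon would help to show. As far as these compounds go, all three compounds also share the same core, so it remains open how an amine or a carboxylic acid elsewhere would behave.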